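This account rests on a few compounds, and the source may have more. Where it says the series, first, only, none or still open, it means among the compounds named here.

Measured so far in a functional assay on NCI-H460 cells (Homo sapiens) for antiproliferative activity; on this read-out higher numbers stand for weaker inhibition and lower numbers for stronger inhibition:
Compound 1 `Cc1ccccc1/N=C1\NC(=O)/C(=C\c2ccc(N(C)C)cc2)S1`: 650 nM
Compound 2 `CN(C)c1ccc(/C=C2/S/C(=N/c3ccc(Cl)cc3)NC2=O)cc1`: 2890 nM
Compound 3 `Cc1ccc(N=C2NC(=O)/C(=C\c3ccc(N(C)C)cc3)S2)cc1`: 940 nM

Compound 3, at 940 nM, lies within the scatter of compound 1, at 650 nM. Compound 2, at 2890 nM, lies beyond the scatter of both.

Compound 4 `CN(C)c1ccc(/C=C2/SC(=Nc3ccccc3)NC2=O)cc1` has not been measured. It differs from compound 3 as follows: hydrogen in place of methyl on an aromatic carbon. In words, hydrogen replaces methyl on an aromatic carbon, so 4-methylphenyl becomes phenyl.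

For the measured compounds named here, only one measured step changes this group, a 4.4-fold higher number from compound 1 to compound 2 (0.65 log units; beyond the scatter). That step is modest and swaps a different pair of groups, so it offers only loose guidance. No step beyond the scatter is expected in this assay, in either direction.

The expected step is a 1.1-fold higher number from compound 3 to compound 4 (0.05 log units; within the scatter).

For compound 4 the estimated value is 1050 nM, with an expected range of 430 nM to 2600 nM.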

Compound 4, half-maximal inhibitory concentration: 500 nM
For compound 4 the middle estimate is 2.1-fold (0.32 log units) above the measured one; the measured number falls inside the stated range.
By their numbers in this assay, from the lowest: compounds 4, 1 and 3 (each within the scatter of the next); then compound 2.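

In this assay, taking away the methyl group, so that 4-methylphenyl becomes phenyl, gives a 1.9-fold lower number from compound 3 to compound 4 (0.27 log units; within the scatter). The methyl group at this place on the aromatic ring can therefore be removed without a step beyond the scatter, and the plain phenyl compound still works in this cell assay. Nothing at hand explains this result. Still open, going by these compounds, is how a methoxy group, an amine or a carboxylic acid at this same place would read in this assay.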